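The source may report more compounds than this note shows. Statements on the series, on what has been measured and on what is new or still open speak of the compounds shown alone.

Measured compounds:
compound 1 `O=C1/C(=C\c2cc[n+]([O-])cc2)c2ccccc2N1Cc1ccccc1` gives 43.4%
compound 2 `CC(c1ccccc1)N1C(=O)/C(=C\c2cccnc2)c2ccccc21` gives 87%
compound 3 `O=C1/C(=C\c2ccc3ccccc3n2)c2ccccc2N1Cc1ccccc1` gives 55.7%

The three compounds share one core and were compared in a functional assay on HL-60 cells (Homo sapiens) for cytotoxicity, read by MTT assay, with a stated time of 72 h, tested at 2.5 uM; on this read-out lower numbers stand for a stronger effect and higher numbers for a weaker effect at the one concentration tested. Compound 3 stands second highest of the three numbers. Its nearest neighbour is compound 1, whose number lies lower, beyond the usual scatter, so compound 1 shows the stronger effect of the two. Furthest from compound 3 lies compound 2, whose number is higher, again beyond the scatter, so compound 2 shows the weaker effect. Nothing beyond these two values is known for either pair.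

Compound 4 `CC(c1ccccc1)N1C(=O)/C(=C\c2ccc3ccccc3n2)c2ccccc21` has not been measured in this assay. It differs from compound 3 in one place: methyl in place of hydrogen on a saturated chain carbon bound to an amide-type nitrogen in a ring and an aromatic carbon. Among the measured compounds shown here, no pair of measured compounds isolates this change, so its effect is not known directly. Compound 2, which carries the entering group, gives the weakest read-out of the three in this assay, while compound 3 with the leaving group gives 55.7%. On that basis compound 4 is expected to give a somewhat higher number than compound 3, a step of a number 12.3 percentage points higher from compound 3 to compound 4 (beyond the scatter), towards a weaker effect, though the scatter may cover part of it. The estimate for compound 4 in this assay is 68%, with a range from 50% to 88%.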

Compound 4, a percentage reported as activity, at one concentration (the size of the read-out at that concentration, not a potency): 81.3%
For compound 4 the middle estimate is 13.3 percentage points below the measured one; the range from low to high includes it.
By their numbers in this assay, from the lowest: compound 1; then compound 3; then compounds 4 and 2 (each within the scatter of the next).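

In this assay, among the compounds shown here, the first pair of compounds differing in one place gives a direct reading of this position: the change from benzyl to 1-phenylethyl, methyl in place of hydrogen on a saturated chain carbon bound to an amide-type nitrogen in a ring and an aromatic carbon, reads a number 25.6 percentage points higher from compound 3 to compound 4 (beyond the scatter) towards a weaker effect. A single added methyl, one heavy atom with no ring, no hydrogen-bond donors or acceptors and no net charge, is therefore enough to move the read-out at the one concentration tested, and this holds for this one pair only. No measurement shown bears on why the step arises.

The compounds shown leave open whether a longer chain such as ethyl on this carbon, or a hydroxyl group in place of the methyl, would move the number further or bring it back. For the compounds shown here, they also leave open whether the same change would give a step of similar size on the core of compound 1, where no such pair is available.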